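Removing the Bromine from a Potent EP1 Antagonist

The source may report more compounds than this note shows. Statements on the series, on what has been measured and on what is new or still open speak of the compounds shown alone.

Measured compounds:
compound 1, `Cc1cc(C(=O)O)nn1Cc1cc(Br)ccc1OCc1ccc(Cl)cc1Cl`, 0.49 nM
compound 2, `Cc1cc(C(=O)O)nn1Cc1cc(Br)ccc1OCc1ccc(Cl)cc1`, 8.71 nM
compound 3, `Cc1cccc(COc2ccc(Br)cc2Cn2nc(C(=O)O)cc2C)c1`, 525 nM

In a functional assay on CHO-K1 cells for antagonist activity at prostaglandin E2 receptor EP1 subtype (Homo sapiens), read by FLIPR (on this read-out lower numbers stand for stronger inhibition and higher numbers for weaker inhibition), compound 1 gives the lowest of the three numbers. Its nearest neighbour is compound 2, reached by an 18-fold higher number from compound 1 to compound 2 (1.25 log units; beyond the scatter), and the furthest is compound 3, reached by a 1100-fold higher number from compound 1 to compound 3 (3.03 log units; beyond the scatter). The remaining measured step is a 60-fold higher number from compound 2 to compound 3 (1.78 log units; beyond the scatter).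

Compound 4, `Cc1cc(C(=O)O)nn1Cc1ccccc1OCc1ccc(Cl)cc1Cl`, differs from compound 1 in one place: hydrogen in place of bromo on an aromatic carbon, on an aromatic carbon of a six-membered aromatic ring of carbon only, meta to a large group and para to a large group. Among the measured compounds shown here, no measured step touches this bromo; the three measured steps all concern the aryl group on the saturated chain carbon bound to the ring oxygen. For the measured compounds named here, the only guide is that loss of a halogen elsewhere in the molecule, as in an 18-fold higher number from compound 1 to compound 2 (1.25 log units; beyond the scatter), weakened inhibition clearly. For compound 4 a weakening of moderate size is therefore expected, a 10-fold higher number from compound 1 to compound 4 (1.01 log units; beyond the scatter), though with wide uncertainty.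

Compound 4 is estimated at 5 nM in this assay, within a range from 1 nM to 30 nM.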

Compound 4, inhibition constant: 8.32 nM
Compound 4: the middle estimate sits 1.7-fold (0.22 log units) below what was measured; measured number inside the range.
By their numbers in this assay, from the lowest: compound 1; then compounds 4 and 2 (each within the scatter of the next); then compound 3.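

The bromo on the aromatic carbon meta to a large group and para to a large group is no spare substituent: in this assay, hydrogen in its place gives a 17-fold higher number from compound 1 to compound 4 (1.23 log units; beyond the scatter). Among the compounds shown here, the change removes a single heavy atom and no hydrogen-bond donor or acceptor, yet the step is large, so this position matters as well as the aryl group that the earlier compounds varied. Compound 1 thus loses much by giving up either halogen, since the chloro step, an 18-fold higher number from compound 1 to compound 2 (1.25 log units; beyond the scatter), is also large, and nothing shown explains why either atom counts for so much.

On these data alone, whether chloro, methyl or a nitrile on this carbon would keep the number of compound 1 remains open. So does whether losing the bromo would cost as much with the 4-chlorophenyl of compound 2 or the 3-methylphenyl of compound 3.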